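The source may hold more compounds than are shown below. What is called first, only, known or untested is meant among the compounds shown, and "the series" means these compounds.

Working notes on the series.

Compound 2 `O=C(CCCCC#Cc1cccc(Cl)c1Cl)c1ncc(-c2ccccn2)o1` is the anchor for this step. In an assay for inhibition of Fatty-acid amide hydrolase 1 (Rattus norvegicus) (on this read-out higher numbers stand for weaker inhibition and lower numbers for stronger inhibition), compound 2 gives 5 nM, the lowest of the three numbers in hand. Compound 1 `O=C(CCCCC#Cc1ccccn1)c1ncc(-c2ccccn2)o1` gives 280 nM in this assay, and compound 3 `CC(C)(C)OC(=O)Nc1ccc(C#CCCCCC(=O)c2ncc(-c3ccccn3)o2)cc1` gives 23 nM; both sit above compound 2, compound 3 nearer and compound 1 furthest away.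

The candidate is compound 4 `O=C(CCCCC#Cc1cccc([N+](=O)[O-])c1)c1ncc(-c2ccccn2)o1`. Its difference from compound 2 is 3-nitrophenyl in place of 2,3-dichlorophenyl on a triple-bonded carbon.

Among the measured compounds shown here, only one measured step touches this position directly: a 56-fold lower number from compound 1 to compound 2 (1.75 log units; beyond the scatter), which shows that the group on the triple-bonded carbon carries a large effect, with pyridin-2-yl far weaker than 2,3-dichlorophenyl. For the measured compounds named here, no step between compound 3 and compound 2 is on record; their values alone show that a phenyl bearing a carbamate lands between the pyridin-2-yl and the 2,3-dichlorophenyl compounds. Exchanging 2,3-dichlorophenyl for 3-nitrophenyl is therefore expected to give a step upward in this assay, of moderate size, a 6.0-fold higher number from compound 2 to compound 4 (0.78 log units; beyond the scatter), since the two chlorines are lost and a substituted phenyl of the kind seen in compound 3 remains.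

Compound 4 is estimated at 30 nM in this assay, within a range of 8 nM to 120 nM.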

Compound 4, inhibition constant: 4.8 nM
Compound 4: middle estimate off by 6.3-fold (0.80 log units), on the high side, outside the stated range (below it).
By their numbers in this assay, from the lowest: compounds 4 and 2 (each within the scatter of the next); then compound 3; then compound 1.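

In this assay, 3-nitrophenyl in place of 2,3-dichlorophenyl on the triple-bonded carbon gives a 1.0-fold lower number from compound 2 to compound 4 (0.02 log units; within the scatter), so compound 2 and compound 4 cannot be told apart, and the two chlorines are not needed for a number at this level. Set against pyridin-2-yl, the same 3-nitrophenyl gives a 58-fold lower number from compound 1 to compound 4 (1.77 log units; beyond the scatter), which shows that the large step at this position is not tied to 2,3-dichlorophenyl and appears with two phenyl groups of different substitution, one with chlorine atoms and one with nitrogen and oxygen atoms. Nothing on record gives a reason why these two groups match or why both stand so far from pyridin-2-yl.

The compounds shown leave open where a plain phenyl would stand on this triple-bonded carbon, and so how much of the step belongs to the carbon ring itself and how much to its substituents. They also leave open how an amine or a carboxylic acid in place of the nitro group would read in this assay, and what a longer chain would do to these values.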